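The source may hold more compounds than are shown below. What is called first, only, known or untested is meant among the compounds shown, and "the series" means these compounds.

Measured so far:
compound 1 `Fc1ccc(C(OCC2CCN(CCCc3ccccc3)CC2)c2ccc(F)cc2)cc1`, 13 nM
compound 2 `c1ccc(CN2CCC(COC(c3ccccc3)c3ccccc3)CC2)cc1`, 702 nM

In an assay on striatum for binding affinity to sodium-dependent dopamine transporter (Rattus norvegicus) (on this read-out higher numbers stand for weaker inhibition and lower numbers for stronger inhibition), compound 1 gives 13 nM, the lowest of the two numbers; compound 2 gives 702 nM, a higher number well beyond the scatter, though the two structures differ in more than one place. Compound 3 `Fc1ccc(C(OCC2CCN(Cc3ccccc3)CC2)c2ccc(F)cc2)cc1` has not been measured yet. It differs from compound 1 by phenyl in place of phenethyl on a saturated chain carbon bound to an amine nitrogen in a ring. For the measured compounds named here, no measured pair covers this change alone, so the expectation rests on the values of compound 1 and compound 2: a step toward weaker inhibition, beyond the scatter, is expected, a 12-fold higher number from compound 1 to compound 3 (1.06 log units; beyond the scatter). Compound 3 is estimated at 150 nM, within 40 nM to 600 nM.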

Compound 3, half-maximal inhibitory concentration: 126 nM
For compound 3 the middle estimate is 1.2-fold (0.08 log units) above the measured one; the range from low to high includes it.
By their numbers in this assay, from the lowest: compound 1; then compound 3; then compound 2.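

In this assay, replacing 3-phenylpropyl with benzyl on the ring amine nitrogen, with the rest of the core of compound 1 unchanged, gives a 9.7-fold higher number from compound 1 to compound 3 (0.99 log units; beyond the scatter), a step beyond the scatter. This isolates the effect of this position, which the earlier pair, differing in more than one place, could not show. Nothing available explains the size of this step. The compounds shown leave open how a longer chain such as 4-phenylbutyl would read here. They also leave open how an amide in place of the ring amine would read.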